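A few compounds are considered here, and "the series" means these few. Any claim that something is new, unique, unknown or untested is made for them only; others in the source may bear on it.

Measured so far:
compound 1, `CCCNc1nc(C(C)c2c(F)cccc2F)c(C)c(=O)[nH]1`: 35000 nM
compound 2, `CC1CCCN(c2nc(Cc3c(F)cccc3F)cc(=O)[nH]2)C1`: > 78000 nM

For the measured compounds named here, in an ADME assay on MT4 cells (Homo sapiens) for cytotoxicity, read by MTT assay, with a stated time of 4 days (a higher number here means that more compound is tolerated, a lower number that less compound is tolerated), compound 1 gives 35000 nM, the only plain number in the set. For compound 2 the result is a limit of the assay, (the limit of > 78000 nM in this assay, at which 1 of the 2 values shown sits), and not a number. Compound 1 therefore stands at the single fixed point the series offers, with the other entry sitting at the limit. Going by the values given here, no step between measured compounds is available to calibrate the change in hand.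

The unmeasured compound 3, `Cc1c(C(C)c2c(F)cccc2F)nc(N2CCC(C)CC2)[nH]c1=O`, differs from compound 1 in one place: 4-methylpiperidin-1-yl in place of propylamino on an aromatic carbon. In this assay the expected step is a 1.6-fold higher number from compound 1 to compound 3 (0.20 log units; within the scatter), modest and toward more compound tolerated, and it may well stay within the usual scatter. Compound 3 is estimated at 55000 nM, with a range from 20000 nM to 150000 nM, and a fair chance that only a limit is returned.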

Compound 3, half-maximal cytotoxic concentration: 54000 nM
For compound 3 the middle estimate is 1.0-fold (0.01 log units) above the measured one; the range from low to high includes it.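

In this assay, the aromatic carbon between two ring nitrogen atoms takes 4-methylpiperidin-1-yl in place of propylamino with a step of a 1.5-fold higher number from compound 1 to compound 3 (0.19 log units; within the scatter), so the two compounds cannot be told apart here. This first readable step at this position shows that the hydrogen-bond donor of propylamino can be absent and a six-membered non-aromatic ring present without moving the read-out beyond the scatter. Compound 2 still gives a limit of the assay and not a number, so it adds no second step: the limit of > 78000 nM in this assay, at which 1 of the 3 values shown sits.

This single pair sets no trend for the position, and it says nothing about how far the tolerance of this change extends. As far as these compounds go, whether a morpholine, a primary amine or a carboxylic acid on this carbon would also stay within the scatter of compound 1 remains open.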